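The source may report more compounds than this note shows. Statements on the series, on what has been measured and on what is new or still open speak of the compounds shown alone.

Measured so far:
- compound 1 `O=C(c1ccn2c1CSC2c1cccnc1)c1c[nH]c2cc(-c3ccc(F)cc3)ccc12` — in a functional assay on the whole organism for inhibition, with Rattus norvegicus as the target (a lower number here means that less compound is needed, a higher number that more compound is needed for the effect), compound 1 gives 6.4 mg/kg
- compound 2 `CN(C)C(=O)n1cc(C(=O)c2ccn3c2CSC3c2cccnc2)c2ccc(OCc3ccccc3)cc21` — in this assay compound 2 gives 3.3 mg/kg

Two compounds carry numbers in this assay. Compound 2 stands at the low end of the pair, but its gap to compound 1 lies within the scatter, so the two numbers cannot be told apart on what is shown. Going by the values given here, neither compound differs from the other in a single place, so no step between them is counted.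

Compound 3 `CN(C)C(=O)n1cc(C(=O)c2ccn3c2CSC3c2cccnc2)c2ccc(Cl)cc21` has not been measured in this assay. It differs from compound 2 in one place: chloro in place of benzyloxy on an aromatic carbon. Among the compounds with values here, there is no measured pair that isolates this change, so no step size is available as a reference; what remains is the number for compound 2 and the two-compound spread.

Expectation: with nothing to point in either direction, the step from compound 2 to compound 3 is expected to be a 1.5-fold higher number from compound 2 to compound 3 (0.18 log units; within the scatter), that is, no change beyond the scatter. Compound 3 is accordingly estimated at 5 mg/kg in this assay, within a range from 1.5 mg/kg to 15 mg/kg, the width reflecting the absence of any comparable step.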

Compound 3, dose for half-maximal effect: 1.4 mg/kg
Estimate against measurement, compound 3: 3.6-fold (0.55 log units) above; the whole stated range lies above it.
By their numbers in this assay, from the lowest: compound 3; then compounds 2 and 1 (each within the scatter of the next).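

Going by these compounds alone, at this aromatic carbon, meta to a fused ring and para to a fused ring, chloro in place of benzyloxy gives a 2.4-fold lower number from compound 2 to compound 3 (0.37 log units; beyond the scatter) in this assay and is the only step so far that can be read. The benzyloxy group, with its eight heavy atoms and six-membered aromatic ring, is therefore not required for the effect at this position, since the single chlorine atom of chloro gives a lower number on the otherwise unchanged structure. No measurement is available to explain the step, so the data record its size and direction but not its cause.

A single pair cannot separate the contribution of losing benzyloxy from that of gaining chloro, and it leaves open whether the step would hold on another version of the shared core. Hydrogen, fluoro, bromo, methoxy, a short alkyl chain, an amine or a carboxylic acid at this same carbon would show whether chloro is distinctive or whether a smaller group of almost any kind gives a similar number.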